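Removing one hydroxy from the compound 1 series

The source may hold more compounds than are shown below. What is called first, only, known or untested is meant among the compounds shown, and "the series" means these compounds.

Measured in a functional assay on SF-268 cells (Homo sapiens) for inhibition; a higher number here means a weaker inhibitor of growth, a lower number a stronger inhibitor of growth:
- Compound 1 `NS(=O)(=O)c1ccc(/C=C/c2ccc(O)c(O)c2)cc1` gives 18200 nM
- Compound 2 `COc1cccc(/C=C/c2ccc(S(N)(=O)=O)cc2)c1` gives 17100 nM

Compound 1 and compound 2 lie within the scatter of each other, so the two numbers cannot be separated in this assay. Neither can be called the better growth inhibitor. Compound 1 therefore stands with compound 2 in the same range.

The next compound to be measured is compound 3 `NS(=O)(=O)c1ccc(/C=C/c2ccc(O)cc2)cc1`. Its change from compound 1 is hydrogen in place of hydroxy on an aromatic carbon, ortho to a hydroxy group and meta to a large group.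

Among the measured compounds shown here, no pair of measured compounds differing in one place exists, so this change has no direct precedent. For the measured compounds named here, the only guide is the close pair of values, with compound 1 at 18200 nM and compound 2 at 17100 nM. No step beyond the scatter is expected in this assay, and neither direction is favoured.

The expected change is small, an estimated 1.1-fold lower number from compound 1 to compound 3 (0.03 log units; within the scatter). For compound 3 the estimated value is 17000 nM, with an expected range of 6000 nM to 45000 nM.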

Compound 3, concentration for 50% growth inhibition: 31500 nM
For compound 3 the middle estimate is 1.9-fold (0.27 log units) below the measured one, within the range that was stated.
By their numbers in this assay, from the lowest: compounds 2, 1 and 3 (each within the scatter of the next).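

In this assay, hydrogen in place of hydroxy on an aromatic carbon, ortho to a hydroxy group and meta to a large group, gives a 1.7-fold higher number from compound 1 to compound 3 (0.24 log units; within the scatter). Among the compounds shown here, this is the first step between compounds that differ in one place, and it gives no sign that the lost hydroxy matters at this position, since a step within the scatter cannot be told from no change at all. Compound 1 and compound 3 therefore remain in one range in this assay, and no evidence at hand bears on what the hydroxy does here.

From the compounds shown here alone, whether any other group on this aromatic carbon, such as an amine, a fluorine atom or a carboxylic acid, would produce a step beyond the scatter remains open, as does the outcome of replacing the hydroxy that remains in compound 3. For the compounds shown here, compound 2 differs from compound 1 and from compound 3 in more than one place, so it gives no step to read, and the series so far offers no single-place change with a clear effect on growth inhibition.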